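Propanoyl in place of fluorobenzoyl on a piperazine amide

The compounds below may be only part of what the source reports. "The series", "measured", "known", "first", "only" and "open" are said of these compounds alone.

Measured so far:
- compound 1 `O=C(c1ccccc1F)N1CCN(c2nc(=O)c3cc(C(F)(F)F)cc([N+](=O)[O-])c3s2)CC1`: in an ADME assay on Vero cells (Chlorocebus sabaeus) for cytotoxicity, read by MTT assay, with a stated time of 72 h (on this read-out lower numbers stand for higher toxicity in this test and higher numbers for lower toxicity in this test), compound 1 gives > 125000 nM, which is a limit of the test.
- compound 2 `CC(C)CC(=O)N1CCN(c2nc(=O)c3cc(C(F)(F)F)cc([N+](=O)[O-])c3s2)CC1`: in this assay compound 2 gives > 125000 nM, again a limit.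
- compound 3 `O=C(c1ccc(F)cc1)N1CCN(c2nc(=O)c3cc(C(F)(F)F)cc([N+](=O)[O-])c3s2)CC1`: in this assay compound 3 gives > 125000 nM, also a limit.

Compound 3 therefore stands at the limit of the assay, and the two other values shown stand at the same limit, as the limit of > 125000 nM in this assay, at which 3 of the 3 values shown sit, records. The steps between the measured compounds are a step that the two limits leave unreadable from compound 1 to compound 2, a step that the two limits leave unreadable from compound 1 to compound 3 and a step that the two limits leave unreadable from compound 2 to compound 3; none of them can be read, since both ends sit at the limit.

The change from compound 3 to compound 4 `CCC(=O)N1CCN(c2nc(=O)c3cc(C(F)(F)F)cc([N+](=O)[O-])c3s2)CC1` is ethyl in place of 4-fluorophenyl on a carbonyl carbon. Every measured step around compound 3 is unreadable, so no size can be derived for this step. All that the three measured compounds show is that an exchange of the acyl group on the carbonyl carbon has not brought any of them below the limit, so the step from compound 3 to compound 4 is expected to be a number no higher from compound 3 to compound 4 (the limit leaves the size open), staying at the limit. Compound 4 is estimated at 125000 nM, within 50000 nM to 250000 nM.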

Compound 4, half-maximal cytotoxic concentration: > 125000 nM
Compound 4 ended at the assay's limit (the forecaster's own chance of this, stated with the estimate: 80%); the middle value lies on the limit itself.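

Compound 4 sits at the limit of this assay, as do compound 1, compound 2 and compound 3, so none of the steps among these four compounds can be read: the limit of > 125000 nM in this assay, at which 4 of the 4 values shown sit. The compounds shown leave open whether exchanging these acyl groups changes cytotoxicity at all.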